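Shifting from isopropyl to hydroxymethyl on the chain of compound 3

This account rests on a few compounds, and the source may have more. Where it says the series, first, only, none or still open, it means among the compounds named here.

Compound 1 `CC[C@@H]1O[C@H](COCc2ccccc2)[C@@H](OCc2ccccc2)[C@H](OCc2ccccc2)[C@H]1O`: 19800 nM
Compound 2 `CCC[C@@H]1O[C@H](COCc2ccccc2)[C@@H](OCc2ccccc2)[C@H](OCc2ccccc2)[C@H]1O`: 18900 nM
Compound 3 `CC(C)C[C@@H]1O[C@H](COCc2ccccc2)[C@@H](OCc2ccccc2)[C@H](OCc2ccccc2)[C@H]1O`: > 50000 nM

In a functional assay on HeLa cells (Homo sapiens) for antiproliferative activity, read by sulforhodamine B assay (a lower number here means a stronger inhibitor of growth, a higher number a weaker inhibitor of growth), compound 1 gives 19800 nM and compound 2 gives 18900 nM; the two sit within the scatter of each other, a 1.0-fold lower number from compound 1 to compound 2 (0.02 log units; within the scatter). For compound 3 the assay reports only a limit, > 50000 nM, which is the upper boundary of the measurement rather than a number (the limit of > 50000 nM in this assay, at which 1 of the 3 values shown sits). On the numbers shown compound 3 therefore stands at the weak end: an at least 2.5-fold higher number from compound 1 to compound 3 (0.40 log units; beyond the scatter), and an at least 2.6-fold higher number from compound 2 to compound 3 (0.42 log units; beyond the scatter).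

Compound 4 `OCC[C@@H]1O[C@H](COCc2ccccc2)[C@@H](OCc2ccccc2)[C@H](OCc2ccccc2)[C@H]1O` has not yet been measured in this assay. It differs from compound 3 in one place: hydroxymethyl in place of isopropyl on a saturated chain carbon bound to a saturated ring carbon. For the measured compounds named here, no measured pair shows hydroxymethyl entering at this position, so the steps that bear on it are those that put isopropyl in, the steps from compound 1 and compound 2 to compound 3, which each raised the number beyond the scatter. Going by the values given here, removing isopropyl would be expected to undo that rise, bringing the value back toward the range of compound 1 and compound 2, while the hydroxymethyl group carries no measured precedent here. Compound 4 is therefore expected to give about 25000 nM in this assay, within roughly 10000 nM to 60000 nM, a step of an at least 2.0-fold lower number from compound 3 to compound 4 (0.30 log units; that floor lies within the scatter) that is estimated rather than observed.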

Compound 4, concentration for 50% growth inhibition: 30200 nM
The estimate for compound 4 lay 1.2-fold (0.08 log units) below the measured number; low and high end bracket the measured number.
By their numbers in this assay, from the lowest: compounds 2, 1 and 4 (each within the scatter of the next). At a limit, above all of these: compound 3.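

Compound 3 remains at a limit of the assay in this assay: the limit of > 50000 nM in this assay, at which 1 of the 4 values shown sits. Hydroxymethyl in place of isopropyl on a saturated chain carbon bound to a saturated ring carbon gives an at least 1.6-fold lower number from compound 3 to compound 4 (0.21 log units; that floor lies within the scatter), so the change yields a measured number at this position, although the floor of that step does not clear the scatter. Set against the chains made of carbon alone, the 2-hydroxyethyl chain of compound 4 stays level, with a 1.6-fold higher number from compound 2 to compound 4 (0.20 log units; within the scatter) and a 1.5-fold higher number from compound 1 to compound 4 (0.18 log units; within the scatter), which shows what the earlier compounds could not: in this assay, a chain carrying a hydroxy group at this position reads the same as those chains within the scatter.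

The compounds shown leave open how an amine or a carboxylic acid in place of hydroxymethyl on the same saturated chain carbon would read in this assay, and whether a longer chain carrying a hydroxy group would stay level with compound 1 and compound 2. They also share one core, so they cannot tell whether this change would read the same on another core.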